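Carboxy replaced by carbamoylmethyl on the side chain

A few compounds are considered here, and "the series" means these few. Any claim that something is new, unique, unknown or untested is made for them only; others in the source may bear on it.

Compound 3 `O=C(O)CCCCOc1cc(-c2ccccc2)cc(-c2ccccc2)n1` gives 50 nM in an assay on cell membranes from spleen (Cavia porcellus) for binding affinity to leukotriene B4 receptor 1 (Homo sapiens) (on this read-out higher numbers stand for weaker inhibition and lower numbers for stronger inhibition), and stands second highest of the three numbers. Compound 1 `O=C(O)CCCCCOc1cc(-c2ccccc2)cc(-c2ccc(F)cc2)n1` gives 30 nM, within the scatter of compound 3, while compound 2 `Cc1ccc(-c2cc(-c3ccccc3)cc(OCCCCCC(=O)O)n2)cc1` gives 300 nM, beyond it. Among the measured compounds shown here, the single step measured within the set, a 10-fold higher number from compound 1 to compound 2 (1.00 log units; beyond the scatter), concerns a group on an aromatic carbon. Compound 4 `NC(=O)CCCCCOc1cc(-c2ccccc2)cc(-c2ccccc2)n1` differs from compound 3 by carbamoylmethyl in place of carboxy on a saturated chain carbon, four bonds along the chain from an oxygen on an aromatic ring. For the measured compounds named here, no measured step touches this part of the structure, so no direct precedent exists. All three measured compounds carry the carboxy; compound 4 does not. A weakening is estimated: a 6.0-fold higher number from compound 3 to compound 4 (0.78 log units; beyond the scatter). Compound 4 is therefore expected at 300 nM, between 60 nM and 1500 nM.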

Compound 4, half-maximal inhibitory concentration: 160 nM
Estimate against measurement, compound 4: 1.9-fold (0.27 log units) above, and the stated range covers the measured number.
By their numbers in this assay, from the lowest: compounds 1 and 3 (each within the scatter of the next); then compounds 4 and 2 (each within the scatter of the next).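

Replacing the carboxy with carbamoylmethyl on this saturated chain carbon gives a 3.2-fold higher number from compound 3 to compound 4 (0.51 log units; beyond the scatter) in this assay, a weakening beyond the scatter. Compound 4 still gives a measurable number without a carboxy, so at this position, in this one pair, the carboxy can be exchanged without loss of the read-out. Nothing available accounts for the size of this step.

The step changes the end group and lengthens the chain together, so the two remain unseparated. On these data alone, a carboxylic acid on the longer chain of compound 4, or a methyl ester or nitrile at its end, remains open.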